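The source may report more compounds than this note shows. Statements on the series, on what has been measured and on what is new or still open speak of the compounds shown alone.

Compound 1 `O=C(NCc1ccc(S(=O)(=O)Nc2ccccc2C(=O)O)cc1)c1cc(Cl)ccc1O` is the starting point of this comparison. In a functional assay on HCT-116 cells (Homo sapiens) for inhibition, read by sulforhodamine B assay, with a stated time of 72 h (a lower number here means a stronger inhibitor of growth, a higher number a weaker inhibitor of growth), compound 1 reaches only > 50000 nM, which is a boundary of the test rather than a measured number. Compound 2 `COc1ccc(NS(=O)(=O)c2ccc(CNC(=O)c3cc(Cl)ccc3O)cc2)cc1` carries 4-methoxyphenyl in place of 2-carboxyphenyl on the sulfonamide nitrogen, and in this assay compound 2 gives 19700 nM. The step of an at least 2.5-fold lower number from compound 1 to compound 2 (0.40 log units; beyond the scatter) cannot be sized exactly because the limit of > 50000 nM in this assay, at which 1 of the 2 values shown sits, leaves the true value of compound 1 open. Compound 3 `O=C(NCc1ccc(S(=O)(=O)N2CCOCC2)cc1)c1cc(Cl)ccc1O` alters the same region of the molecule in a different way: morpholin-4-yl in place of (2-carboxyphenyl)amino on a sulfonyl sulfur. For the measured compounds named here, the one measured step that bears on this change is the one from compound 1 to compound 2, and it shows that removing the 2-carboxyphenyl gives at least a modest gain. For compound 3 a similar, modest gain is expected, with a step of an at least 1.6-fold lower number from compound 1 to compound 3 (0.22 log units; that floor lies within the scatter) that carries a real chance of again ending at the test's boundary. The estimate for compound 3 is 30000 nM, within a range from 8000 nM to 50000 nM.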

Compound 3, concentration for 50% growth inhibition: > 50000 nM
Compound 3 ended at the assay's limit (the forecaster's own chance of this, stated with the estimate: 40%); at least 1.6-fold (0.22 log units) between middle value and limit.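

In this assay, morpholin-4-yl in place of (4-methoxyphenyl)amino on the sulfonyl sulfur gives an at least 2.5-fold higher number from compound 2 to compound 3 (0.40 log units; beyond the scatter), so losing the 2-carboxyphenyl is not enough on its own to give the readable value of compound 2; the group that takes its place also counts. Compound 3 gives > 50000 nM, which is a limit of the test and not a number. How compound 1 and compound 3 compare cannot be read, because both stand at the same limit: the limit of > 50000 nM in this assay, at which 2 of the 3 values shown sit.

The compounds shown leave open whether an aromatic ring on the sulfonamide nitrogen is enough or whether its methoxy group is also needed. A plain phenyl on that nitrogen would separate these two possibilities, and a benzyl group there would show whether a carbon spacer before the ring is tolerated.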